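The source may hold more compounds than are shown below. What is called first, only, known or untested is meant among the compounds shown, and "the series" means these compounds.

Compound 2 `CCN(CC)C(=O)CN(c1ccc(C)cc1)S(=O)(=O)c1cccc(Cl)c1` gives 139 nM in a functional assay on CHO cells for inhibition of Orexin receptor type 2 (Homo sapiens), read by FLIPR and calcium flux; a lower number here means a stronger inhibitor, a higher number a weaker inhibitor. Compound 1 `CCN(CC)C(=O)CN(c1cccc(N(C)C)c1C#N)S(=O)(=O)c1ccc(OC)c(OC)c1` gives 110 nM in this assay. Compound 3 `CCN(C(=O)CN(c1cc(N(C)C)ccc1Cl)S(=O)(=O)c1ccc(OC)c(OC)c1)c1cnc(C)cn1` gives 3 nM in this assay.

Among these three measured compounds, compound 2 has the highest number. Its nearest neighbour is compound 1, whose number is lower by an amount that lies within the usual scatter of repeated measurements, so the two cannot be told apart. Compound 3 stands far away, with a number lower by an amount well beyond the scatter.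

Compound 4 `CCN(CC)C(=O)CN(c1ccc(C)cc1)S(=O)(=O)c1ccc(OC)cc1` has not yet been measured. It differs from compound 2 in one place: 4-methoxyphenyl in place of 3-chlorophenyl on a sulfonyl sulfur. Among the compounds with values here, no pair of measured compounds shows this change on its own, so its effect cannot be read from a direct comparison. Compounds 1 and 3, which also differ from compound 2 in the group on the sulfonyl sulfur, give lower numbers, but they differ from it in other places too, so they offer only a loose hint. The step from compound 2 to compound 4 is expected to be small, a 1.4-fold lower number from compound 2 to compound 4 (0.14 log units; within the scatter), toward a somewhat lower number or none beyond the scatter. Compound 4 is estimated at 100 nM in this assay, within a range from 30 nM to 400 nM.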

Compound 4, half-maximal inhibitory concentration: 661 nM
The estimate for compound 4 lay 6.6-fold (0.82 log units) below the measured number; the measured number lies above the stated range.
By their numbers in this assay, from the lowest: compound 3; then compounds 1 and 2 (each within the scatter of the next); then compound 4.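

In this assay, replacing 3-chlorophenyl with 4-methoxyphenyl on the sulfonyl sulfur, with the rest of the molecule unchanged, gives a 4.8-fold higher number from compound 2 to compound 4 (0.68 log units; beyond the scatter). Within the data shown here, this is the first clean single-place comparison, and it shows that the group at this position can shift the number by more than the usual scatter, here toward weaker inhibition. Nothing shown explains why this change weakens inhibition.

The step changes both the substituent and its place on the ring, so the compounds shown cannot say which of the two matters. Going by these compounds, how an unsubstituted phenyl, or a phenyl carrying an amine or a carboxylic acid, would behave at this position also stays open.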